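This account rests on a few compounds, and the source may have more. Where it says the series, first, only, none or still open, it means among the compounds named here.

Working notes on the series. Compound 1 `COc1cccc(-n2cc3nc(-c4cccnc4C)n(C[C@H]4CCCN(CC5CCO5)C4)c(=O)c3n2)c1` gives 23 nM in an assay on HEK293 cells for displacement of a labelled ligand from growth hormone secretagogue receptor type 1 (Homo sapiens), with a stated time of 60 min; a lower number here means a stronger inhibitor, a higher number a weaker inhibitor. Among the three numbers measured, compound 1 stands second highest: nearest to it is compound 3 `CCO[C@H](C)CN1CCC[C@H](Cn2c(-c3cccnc3C)nc3cn(-c4cccc(OC)c4)nc3c2=O)C1`, which gives 40 nM, the step being a 1.7-fold higher number from compound 1 to compound 3 (0.24 log units; within the scatter); furthest is compound 2 `COc1cccc(-n2cc3nc(-c4cccnc4C)n(C[C@H]4CCCN(CC5CCCC5)C4)c(=O)c3n2)c1`, which gives 12 nM, the step being a 1.9-fold lower number from compound 1 to compound 2 (0.28 log units; within the scatter). Between those two, a 3.3-fold higher number from compound 2 to compound 3 (0.52 log units; beyond the scatter).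

Compound 4 `COC[C@H](C)N1CCC[C@H](Cn2c(-c3cccnc3C)nc3cn(-c4cccc(OC)c4)nc3c2=O)C1` differs from compound 1 at the amine nitrogen in the six-membered non-aromatic ring: 1-(methoxymethyl)ethyl in place of (oxetan-2-yl)methyl on an amine nitrogen in a ring. The group that leaves carries one four-membered non-aromatic ring with one hetero atom; the group that enters has no ring and one defined stereocentre, the acceptor count staying the same.

For the measured compounds named here, the step that bears most closely on this change is the one from compound 1 to compound 3, where 1-ethoxyethyl took the place of oxetan-2-yl on a saturated chain carbon bound to an amine nitrogen in a ring and gave a 1.7-fold higher number from compound 1 to compound 3 (0.24 log units; within the scatter). The step to compound 2, with cyclopentyl at the same place, gave a 1.9-fold lower number from compound 1 to compound 2 (0.28 log units; within the scatter). Both replacements at this position stayed within the scatter, so for compound 4 no step beyond the scatter is expected in this assay, with a slight lean toward a higher number as in compound 3; the expected step is a 1.3-fold higher number from compound 1 to compound 4 (0.12 log units; within the scatter). Compound 4 is estimated at 30 nM, with a range of 12 nM to 75 nM.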

Compound 4, half-maximal inhibitory concentration: 1.7 nM
For compound 4 the middle estimate is 18-fold (1.25 log units) above the measured one, outside the stated range (below it).
By their numbers in this assay, from the lowest: compound 4; then compounds 2, 1 and 3 (each within the scatter of the next, the first and the last beyond it).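

At the amine nitrogen in a ring, the replacements in compound 2 and compound 3 stayed within the scatter of compound 1 in this assay, but 1-(methoxymethyl)ethyl gives a 14-fold lower number from compound 1 to compound 4 (1.13 log units; beyond the scatter) with no change in the counted heavy atoms or acceptors, so this position can carry a large step and compound 4 is the strongest inhibitor of the four. An open chain bearing an alkoxy group is not enough in itself: compound 3 goes against that reading, as 1-(methoxymethyl)ethyl in place of 2-ethoxypropyl gives a 24-fold lower number from compound 3 to compound 4 (1.37 log units; beyond the scatter) and the same group in place of cyclopentylmethyl gives a 7.1-fold lower number from compound 2 to compound 4 (0.85 log units; beyond the scatter) as a smaller but still clear step. No measurement accounts for this gain in binding, so the result stands as an observation without an explanation.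

The compounds shown leave open whether the defined stereocentre of 1-(methoxymethyl)ethyl matters, as its opposite configuration does not appear among them. They also leave open whether the methoxy group is needed, which isopropyl or a longer chain such as 1-(ethoxymethyl)ethyl on the same nitrogen would test.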